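This account rests on a few compounds, and the source may have more. Where it says the series, first, only, none or still open, it means among the compounds named here.

Compound 3 `COc1cc(Cl)cc(-c2nn(-c3cccc(NC(=O)Nc4ccc(Cl)c(Cl)c4)c3)cc2-c2ccncc2)c1` gives 88% in a functional assay on UO-31 cells (Homo sapiens) for inhibition, read by sulforhodamine B assay, with a stated time of 48 h, tested at 1 uM (a lower number here means a stronger effect, a higher number a weaker effect of the compound at the concentration tested), the highest of the three numbers measured. Compound 1 `O=C(Nc1cccc(-n2cc(-c3ccncc3)c(-c3cc(O)cc(Cl)c3)n2)c1)Nc1ccc(Cl)c(Cl)c1`, which differs from it only in the methyl in place of hydrogen on an oxygen on an aromatic ring, gives 78%; the step of a number 10 percentage points higher from compound 1 to compound 3 (within the scatter) is small. Within the data shown here, compound 2 `COc1cc(Cl)cc(-c2nn(-c3cccc(NC(=O)Nc4cc(C(F)(F)F)cc(C(F)(F)F)c4)c3)cc2-c2ccncc2)c1` gives 15%, far lower, and it differs from compound 3 only in the aryl group on the urea, for which no single step is set out. Compound 4 `COc1cc(Cl)cc(-c2nn(-c3cccc(NC(=O)c4cccc(C(F)(F)F)c4)c3)cc2-c2ccncc2)c1` carries the change (3-(trifluoromethyl)phenyl in place of (3,4-dichlorophenyl)amino on a carbonyl carbon). Among the measured compounds shown here, no measured step touches this position, so the change from compound 3 cannot be read off directly; the low number of compound 2 shows that the same end of the molecule can move the read-out a long way. Compound 4 is therefore expected to give roughly 60%, between 25% and 95%, a step of a number 28 percentage points lower from compound 3 to compound 4 (beyond the scatter) whose direction is uncertain.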

Compound 4, a percentage reported as activity, at one concentration (the size of the read-out at that concentration, not a potency): 54%
Compound 4: middle estimate off by 6 percentage points, on the high side; the measured number falls inside the stated range.
By their numbers in this assay, from the lowest: compound 2; then compound 4; then compounds 1 and 3 (each within the scatter of the next).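

The change from (3,4-dichlorophenyl)amino to 3-(trifluoromethyl)phenyl on a carbonyl carbon gives a number 34 percentage points lower from compound 3 to compound 4 (beyond the scatter) in this assay, so a single change at this position moves the read-out beyond the scatter. It removes a group with one hydrogen-bond donor and enters one with none, while the substituents on the ring change as well. Nothing available here explains the step. The compounds shown leave open whether the donor or the ring substituents account for it, and what a (3-(trifluoromethyl)phenyl)amino group on this carbonyl carbon would give.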